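From pyrimidin-5-yl to phenyl on the shared core

The source may hold more compounds than are shown below. What is called first, only, known or untested is meant among the compounds shown, and "the series" means these compounds.

Measured in a functional assay on CWR22R cells (Homo sapiens) for antiproliferative activity, read by CCK-8 assay, with a stated time of 6 days (on this read-out higher numbers stand for weaker inhibition and lower numbers for stronger inhibition), so far:
Compound 1 `CCN(c1cccc(-c2ccccc2)c1)c1ccc(C#N)c(Cl)c1` gives "not determined" (no result reported) here
Compound 2 `CCN(c1ccc(C#N)c(Cl)c1)c1cc(-c2cncnc2)ccc1C` gives > 30000 nM here

Compound 2 stands at > 30000 nM in this assay and this is a limit of the assay, not a number. Among the measured compounds shown here, compound 1 has no result, so no measured pair is available for comparison. Compound 3 `CCN(c1ccc(C#N)c(Cl)c1)c1cc(-c2ccccc2)ccc1C` carries phenyl in place of pyrimidin-5-yl on an aromatic carbon, para to a methyl group (phenyl in place of pyrimidin-5-yl on an aromatic carbon). With only the limit of > 30000 nM in this assay, at which 1 of the 2 values shown sits, to start from, the expected change is an estimated step of an at least 5.0-fold lower number from compound 2 to compound 3 (0.69 log units; beyond the scatter) toward stronger inhibition, of a size beyond the scatter. For the measured compounds named here, no measured step supports this expectation, so it remains uncertain, and another limit is possible. For compound 3 the estimated value is 6000 nM in this assay, with an expected range from 1000 nM to 30000 nM on this read-out.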

Compound 3, half-maximal inhibitory concentration: > 30000 nM
Compound 3 ended at the assay's limit (the forecaster's own chance of this, stated with the estimate: 30%); at least 5.0-fold (0.69 log units) between middle value and limit.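

In this assay compound 2 and compound 3 both end at a limit and not at a number, so no step can be read for phenyl in place of pyrimidin-5-yl: the limit of > 30000 nM in this assay, at which 2 of the 3 values shown sit.

The compounds shown leave open whether this exchange changes inhibition at all.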